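A few compounds are considered here, and "the series" means these few. Any claim that something is new, unique, unknown or untested is made for them only; others in the source may bear on it.

In a functional assay (blood) for inhibition, with Homo sapiens as the target (a lower number here means a stronger inhibitor, a higher number a weaker inhibitor), compound 1 `CC(C)(C)Sc1c(CC(C)(C)C(=O)O)n(Cc2ccc(Cl)cc2)c2ccc(OCc3ccc4cc(F)c(F)cc4n3)cc12` reads > 3000 nM, which is a limit of the assay and not a number. Among the measured compounds shown here, compound 2 `CC(C)(C)Sc1c(CC(C)(C)C(=O)O)n(Cc2ccc(Cl)cc2)c2ccc(OCc3cccc(Cl)n3)cc12` gives 410 nM, the only exact value so far, so it is the sole firm reference point. Compound 3 `CC(C)(C)Sc1c(CC(C)(C)C(=O)O)n(Cc2ccc(Cl)cc2)c2ccc(OCc3cnccn3)cc12` carries pyrazin-2-yl in place of 6-chloropyridin-2-yl on a saturated chain carbon bound to an oxygen on an aromatic ring. For the measured compounds named here, one measured step bears on this place: an at least 7.3-fold lower number from compound 1 to compound 2 (0.86 log units; beyond the scatter). It shows that changes here can matter, but it involved a different and larger group, and one end of it is only a limit. It therefore offers little guide to the size or direction of this swap. The expected change is modest: a 1.5-fold higher number from compound 2 to compound 3 (0.17 log units; within the scatter). For compound 3 the estimated value is 600 nM, with an expected range from 200 nM to 2000 nM.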

Compound 3, half-maximal inhibitory concentration: 400 nM
The estimate for compound 3 lay 1.5-fold (0.18 log units) above the measured number, and the stated range covers the measured number.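

In this assay, pyrazin-2-yl in place of 6-chloropyridin-2-yl gives a 1.0-fold lower number from compound 2 to compound 3 (0.01 log units; within the scatter), so the two groups cannot be told apart at this position. The chlorine of compound 2 is therefore not required for this level of inhibition when pyrazin-2-yl takes its place. Pyrazin-2-yl in place of the larger two-ring group gives an at least 7.5-fold lower number from compound 1 to compound 3 (0.87 log units; beyond the scatter), which matches what 6-chloropyridin-2-yl showed earlier, and the true size of this step stays unknown: the limit of > 3000 nM in this assay, at which 1 of the 3 values shown sits.

As far as these compounds go, it remains open whether the weak result of compound 1 comes from its second ring or from its two fluorine atoms, which the same two-ring group without fluorine could separate. From the compounds shown here alone, it is also open whether this saturated chain carbon would tolerate a group with no aromatic ring, such as an amine or a carboxylic acid.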